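Bromo Added to the Core: Compound 3 to Compound 4

A few compounds are considered here, and "the series" means these few. Any claim that something is new, unique, unknown or untested is made for them only; others in the source may bear on it.

compound 1 `C=C1C[C@]23C[C@@]1(O)CC[C@H]2c1cc(Br)c(O)c(C)c1[C@@H]3Cn1cc(-c2ccccc2)nn1` — > 20000 nM
compound 2 `C=C1C[C@]23C[C@@]1(O)CC[C@H]2c1cc(Br)c(O)c(C)c1[C@@H]3Cn1cc(-c2ccc(Cl)cc2)nn1` — 10500 nM
compound 3 `C=C1C[C@]23C[C@@]1(O)CC[C@H]2c1ccc(O)c(C)c1[C@@H]3Cn1cc(-c2ccc(C(F)(F)F)cc2)nn1` — 10400 nM

In a functional assay on A549 cells (Homo sapiens) for cytotoxicity, read by MTT assay, with a stated time of 4 days (a lower number here means a stronger inhibitor, a higher number a weaker inhibitor), compound 3 gives 10400 nM, one of the two numbers measured; compound 2, at 10500 nM, sits within the scatter of it. For compound 1 only the limit of > 20000 nM in this assay, at which 1 of the 3 values shown sits, is reported, a limit rather than a number. Compound 4 `C=C1C[C@]23C[C@@]1(O)CC[C@H]2c1cc(Br)c(O)c(C)c1[C@@H]3Cn1cc(-c2ccc(C(F)(F)F)cc2)nn1` differs from compound 3 by bromo in place of hydrogen on an aromatic carbon. Going by the values given here, no measured step changes this position. Among the compounds with values here, the single measured step, an at least 1.9-fold lower number from compound 1 to compound 2 (0.27 log units; that floor lies within the scatter), alters the phenyl ring instead and has a floor within the scatter. Compound 2, which carries the bromo group, gives 10500 nM, and compound 3 without it gives 10400 nM. Compound 4 is therefore expected to show a 1.0-fold higher number from compound 3 to compound 4 (0.00 log units; within the scatter), nothing beyond the scatter. Compound 4 is estimated at 10500 nM, between 4000 nM and 25000 nM.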

Compound 4, half-maximal inhibitory concentration: 9280 nM
The estimate for compound 4 lay 1.1-fold (0.05 log units) above the measured number; measured number inside the range.
By their numbers in this assay, from the lowest: compounds 4, 3 and 2 (each within the scatter of the next). At a limit, above all of these: compound 1.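

Going by these compounds alone, at this position, the only measured step puts bromo in place of hydrogen on an aromatic carbon, ortho to a hydroxy group, and it gives a 1.1-fold lower number from compound 3 to compound 4 (0.05 log units; within the scatter). With bromo present, trifluoromethyl in place of chloro gives a 1.1-fold lower number from compound 2 to compound 4 (0.05 log units; within the scatter), whereas trifluoromethyl in place of hydrogen gives an at least 2.1-fold lower number from compound 1 to compound 4 (0.33 log units; beyond the scatter). That last step starts from a limit for compound 1, not a number: the limit of > 20000 nM in this assay, at which 1 of the 4 values shown sits.

The compounds shown leave open whether an amine or a carboxylic acid on this same aromatic carbon would move the number beyond the scatter.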